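The source may report more compounds than this note shows. Statements on the series, on what has been measured and on what is new or still open speak of the compounds shown alone.

Compound 1 `O=C(COc1cccc2ccc(N3CCCC3)nc12)NCc1ccccc1` was tested in an ADME assay on HEK-293T cells (Homo sapiens) for cytotoxicity, read by CCK-8 assay, with a stated time of 48 h; on this read-out lower numbers stand for stronger inhibition and higher numbers for weaker inhibition. In this assay compound 1 reached the limit of > 100000 nM, which is a limit of the measurement rather than a number (the limit of > 100000 nM in this assay, at which 1 of the 2 values shown sits). A second compound, compound 2 `CC(C)(C)OC(=O)N[C@@H]1CCN(c2ccc3cccc(OCC(=O)NCc4ccccc4)c3n2)C1`, differs from compound 1 by a (tert-butoxycarbonyl)amino in place of hydrogen on a saturated ring carbon, and in this assay compound 2 gives 49900 nM. The step of an at least 2.0-fold lower number from compound 1 to compound 2 (0.30 log units; that floor lies within the scatter) thus starts from a limit and does not rise beyond the usual scatter. Compound 3 `O=C(COc1cccc2ccc(N3CCCC3)nc12)NCc1ccc(Br)cc1` has not yet been measured. It differs from compound 1 by bromo in place of hydrogen on an aromatic carbon. Among the compounds with values here, no measured step touches this part of the structure, and the only step that is known did not go beyond the scatter, so there is no basis for expecting a change of any size. For compound 3 the expected step is therefore a number no higher from compound 1 to compound 3 (the limit leaves the size open), none beyond the scatter. Compound 3 is estimated at 100000 nM, within a range from 40000 nM to 250000 nM, with a good chance that only a limit is reported again.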

Compound 3, half-maximal inhibitory concentration: > 100000 nM
Compound 3: no number, only a limit (the forecaster's own chance of this, stated with the estimate: 60%); the middle value sits exactly at the limit.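

In this assay compound 3 gives > 100000 nM, which is a limit and not a number. Within the data shown here, compound 1 also stands at a limit, so no step between compound 1 and compound 3 can be read: the limit of > 100000 nM in this assay, at which 2 of the 3 values shown sit. The compounds shown leave open whether 4-bromobenzyl in place of benzyl changes the read-out at all, and in which direction.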